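The source may report more compounds than this note shows. Statements on the series, on what has been measured and on what is new or still open speak of the compounds shown alone.

Values in a physicochemical assay for lipophilicity, using the shake flask method, in phosphate buffer, with a stated time of 1 h (on this read-out lower numbers stand for lower lipophilicity and higher numbers for higher lipophilicity), so far:
- Compound 1 `CCCCCCCC(=O)OC[C@H]1O[C@@H](n2cnc3c(N)ncnc32)[C@@H](O)[C@@H]1O` gives >= 2 as a limit of the assay and not a number
- Compound 2 `CCCCC(=O)OC[C@H]1O[C@@H](n2cnc3c(N)ncnc32)[C@@H](O)[C@@H]1O` gives 1.33 on this read-out
- Compound 3 `CC(C)CC(=O)OC[C@H]1O[C@@H](n2cnc3c(N)ncnc32)[C@@H](O)[C@@H]1O` gives 1.39 on this read-out

Compound 3 stands level with compound 2 in this assay, the gap being only a number 0.06 log units higher from compound 2 to compound 3 (within the scatter) and giving no order between them. The only other result, that of compound 1, is a limit.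

The next ester, compound 4 `CCCCCC(=O)OC[C@H]1O[C@@H](n2cnc3c(N)ncnc32)[C@@H](O)[C@@H]1O`, has yet to be measured. The change is butyl in place of isopropyl on a saturated chain carbon bound to a carbonyl carbon and amounts to butyl in place of isopropyl on a saturated chain carbon bound to a carbonyl carbon.

Among the measured compounds shown here, three steps bear on this. Propyl and isopropyl at that place are separated by a number 0.06 log units higher from compound 2 to compound 3 (within the scatter) and so offer no sign that the branched chain alone matters. Compound 1 carries hexyl there, and a number at least 0.61 log units lower from compound 1 to compound 3 (beyond the scatter) is matched by a number at least 0.67 log units lower from compound 1 to compound 2 (beyond the scatter) on the way to compound 2. Both of these steps start from a limit and give only a minimum size.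

Butyl lies between propyl and hexyl in length, so a rise beyond the scatter is expected, covering part of the way towards compound 1. The expected change is a number 0.46 log units higher from compound 3 to compound 4 (beyond the scatter) by this estimate. For compound 4 the estimated value is 1.85 with an expected range from 1.55 to 2.15 on measurement.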

Compound 4, partition coefficient: 1.78
Estimate against measurement, compound 4: 0.07 log units above; the measured number falls inside the stated range.
By their numbers in this assay, from the lowest: compounds 2 and 3 (each within the scatter of the next); then compound 4. At a limit, above all of these: compound 1.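

In this assay, propyl and isopropyl on a saturated chain carbon bound to a carbonyl carbon could not be told apart, as a number 0.06 log units higher from compound 2 to compound 3 (within the scatter) shows, whereas butyl at this place does separate from isopropyl, as a number 0.39 log units higher from compound 3 to compound 4 (beyond the scatter) shows. The unbranched pair gives a step of similar kind, methyl in place of hydrogen on a saturated chain carbon, four bonds along the chain from a carbonyl carbon, which reads as a number 0.45 log units higher from compound 2 to compound 4 (beyond the scatter), so among the three measured numbers the longer chain of compound 4 stands apart from both shorter chains. Whether hexyl lies beyond butyl cannot be read from a number at least 0.22 log units lower from compound 1 to compound 4 (that floor lies within the scatter), because that step starts from a limit: the limit of >= 2 in this assay, at which 1 of the 4 values shown sits.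

With a single branched chain among these esters, the compounds shown leave open whether branching stays without consequence on a chain as long as butyl. They also leave open how this assay would read for a chain carrying an amine or a carboxylic acid, or for a cyclohexyl ring in place of butyl.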